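The compounds below may be only part of what the source reports. "The series", "measured", "known", "first", "only" and "open" are said of these compounds alone.

Compounds measured so far:

Compound 1, `Cc1ccc(S/C(=C/c2c[nH]c3ccccc23)C(=O)c2ccc(Br)cc2)cc1`, gives 10000 nM in a functional assay on DU-145 cells (Homo sapiens) for inhibition, read by trypan blue exclusion, with a stated time of 96 h; a higher number here means a weaker inhibitor of growth, a lower number a stronger inhibitor of growth.
Compound 2, `O=C(/C(=C\c1c[nH]c2ccccc12)Sc1ccc(Br)cc1)c1ccc(Br)cc1`, gives 1000 nM in this assay.
Compound 3, `Cc1ccc(S/C(=C/c2c[nH]c3ccccc23)C(=O)c2ccc(Cl)cc2)cc1`, gives 10000 nM in this assay.

For the measured compounds named here, compound 1 stands level with compound 3 at the digits given, and together these two carry the highest numbers of the three; the only step beyond the scatter is a 10-fold lower number from compound 1 to compound 2 (1.00 log units; beyond the scatter), while no change at the digits printed from compound 1 to compound 3 (within the scatter).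

Compound 4, `Cc1ccc(S/C(=C/c2ccc(N(C)C)cc2)C(=O)c2ccc(Br)cc2)cc1`, has not been measured in this assay. It differs from compound 1 in one place: 4-(dimethylamino)phenyl in place of 1H-indol-3-yl on a double-bonded chain carbon bound to a double-bonded chain carbon. The two measured steps both alter a substituent on an aromatic carbon of a phenyl ring and leave the 1H-indol-3-yl untouched, so neither bears on this change. No measured compound carries a 4-(dimethylamino)phenyl at this position, and there is therefore no shown step from which a direction can be taken. The step from compound 1 to compound 4 is accordingly expected to be small, no change at the digits printed from compound 1 to compound 4 (within the scatter), with a wide margin on either side. Compound 4 is estimated at 10000 nM in this assay, within a range of 2000 nM to 50000 nM.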

Compound 4, concentration for 50% growth inhibition: > 100000 nM
Compound 4 gave a limit, no number; the forecaster's own chance of this, stated with the estimate: 30%; middle value at least 10-fold (1.00 log units) from the limit.
By their numbers in this assay, from the lowest: compound 2; then compounds 1 and 3 (each within the scatter of the next). At a limit, above all of these: compound 4.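

Exchanging the 1H-indol-3-yl for 4-(dimethylamino)phenyl on a double-bonded chain carbon bound to a double-bonded chain carbon gives an at least 10-fold higher number from compound 1 to compound 4 (1.00 log units; beyond the scatter), the only step shown at this position, and it is beyond the scatter. For the compounds shown here, the earlier steps changed only a substituent on a phenyl ring, so this is the first sign that growth inhibition also depends on the group at this position. The value for compound 4 in this assay is a limit and not a number: the limit of > 100000 nM in this assay, at which 1 of the 4 values shown sits.

The compounds shown leave open how a 1H-indol-3-yl with a methyl on its nitrogen, or an unsubstituted phenyl, would read at this position, and so which part of the exchange matters. They also leave open whether the same exchange would carry over to the core of compound 2.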